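A few compounds are considered here, and "the series" means these few. Any claim that something is new, unique, unknown or untested is made for them only; others in the source may bear on it.

compound 1 `COc1ccc(N(C)c2cc(C)nc(C)n2)cc1F`: 2790 nM
compound 2 `COc1ccc(N(C)c2cc(C)nc(C)n2)cc1Cl`: 1900 nM

In a functional assay on MDA-MB-231 cells (Homo sapiens) for antiproliferative activity, read by MTT assay, with a stated time of 48 h (a higher number here means a weaker inhibitor, a lower number a stronger inhibitor), compound 2 gives 1900 nM as its value and compound 1 gives 2790 nM as its value, so the two stand level within the scatter and compound 2 holds no real lead.

Within the data shown here, compound 3 `COc1ccc(N(C)c2cc(C)nc(C)n2)cc1[N+](=O)[O-]` has no measurement yet. It carries nitro in place of chloro on an aromatic carbon, ortho to a methoxy group and meta to a large group, and the exchange counts as follows: nitro in place of chloro on an aromatic carbon on that carbon.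

Among the measured compounds shown here, one measured step bears on this. On the same aromatic carbon, chloro in place of fluoro gave a 1.5-fold lower number from compound 1 to compound 2 (0.17 log units; within the scatter) and so stayed within the scatter. For the measured compounds named here, no compound with nitro has a value yet, so the evidence is thin and the range has to stay wide. No step beyond the scatter is therefore expected in this assay and the estimated step is a 1.3-fold higher number from compound 2 to compound 3 (0.12 log units; within the scatter) in size. The expected value in this assay for compound 3 is 2500 nM with an estimated range from 900 nM to 7000 nM around it.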

Compound 3, half-maximal inhibitory concentration: 3440 nM
Compound 3: the middle estimate sits 1.4-fold (0.14 log units) below what was measured; the measured number falls inside the stated range.
By their numbers in this assay, from the lowest: compounds 2, 1 and 3 (each within the scatter of the next).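

In this assay, the carbon ortho to a methoxy group and meta to a large group now has three substituents to compare, and nitro in place of chloro gives a 1.8-fold higher number from compound 2 to compound 3 (0.26 log units; within the scatter), while nitro in place of fluoro gives a 1.2-fold higher number from compound 1 to compound 3 (0.09 log units; within the scatter). Nitro brings 3 heavy atoms and 2 hydrogen-bond acceptors where chloro has 1 heavy atom and 0 hydrogen-bond acceptors, yet both steps stay within the scatter, so compounds 1, 2 and 3 stand level at this position despite that difference in what is counted. Nothing available here accounts for this flat reading.

Still open, from the compounds shown here alone, is whether any group on this carbon would separate from these three, for example an amine, a carboxylic acid or a longer chain. Going by these compounds, all three compounds also share the methoxy group, so it remains unknown whether these exchanges would read the same way with a hydroxyl group in its place.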